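A Thiazole Gives Way to a Piperidine

This account rests on a few compounds, and the source may have more. Where it says the series, first, only, none or still open, it means among the compounds named here.

Compound 3 `Cc1cc(NCc2nccs2)n2nc(C)c(-c3ccccc3)c2n1` holds the only plain number shown in a physicochemical assay for solubility, read by HPLC, using the shake flask method, measured as kinetic solubility, with a stated time of 2 h, at pH 7.4; a higher number here means a more soluble compound, a lower number a less soluble compound: compound 3 gives 108000 nM. Compound 1 `Cc1cc(Nc2ccccn2)n2nc(C)c(-c3ccccc3)c2n1` gives only a limit of the assay, < 5000 nM. Compound 2 `Cc1cc(NCc2ccco2)n2nc(C)c(-c3ccccc3)c2n1` likewise gives only a limit, < 5000 nM. Two steps end at compound 3 and both are large: an at least 21-fold higher number from compound 1 to compound 3 (1.33 log units; beyond the scatter) and an at least 21-fold higher number from compound 2 to compound 3 (1.33 log units; beyond the scatter); their size is known only as a lower bound due to the limit of < 5000 nM in this assay, at which 2 of the 3 values shown sit. Compound 4 `Cc1cc(NCC2CCCCN2)n2nc(C)c(-c3ccccc3)c2n1` differs from compound 3 by piperidin-2-yl in place of 1,3-thiazol-2-yl on a saturated chain carbon bound to a nitrogen on an aromatic ring. Among the measured compounds shown here, no measured step swaps an aromatic group for a saturated ring, so the measured steps give little guidance here, and a change beyond the scatter is not expected in either direction. Compound 4 is therefore estimated at 150000 nM, with an expected range from 40000 nM to 500000 nM, which is expected to mean a 1.4-fold higher number from compound 3 to compound 4 (0.14 log units; within the scatter).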

Compound 4, solubility: 189000 nM
The estimate for compound 4 lay 1.3-fold (0.10 log units) below the measured number; the range from low to high includes it.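

Until now, every group at this place was aromatic. Piperidin-2-yl, a six-membered non-aromatic ring, gives a 1.8-fold higher number from compound 3 to compound 4 (0.24 log units; within the scatter) in this assay and so keeps the high reading of the thiazole, showing that a high number here does not require an aromatic ring on this saturated chain carbon. The other two comparisons give an at least 37-fold higher number from compound 2 to compound 4 (1.57 log units; beyond the scatter) and an at least 37-fold higher number from compound 1 to compound 4 (1.57 log units; beyond the scatter) and are lower bounds only: the limit of < 5000 nM in this assay, at which 2 of the 4 values shown sit.

The compounds shown leave open whether the ring nitrogen of piperidin-2-yl matters. A cyclohexyl group, which has no ring nitrogen, or an open-chain amine at this carbon could test that.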